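Swapping an aromatic ring for a saturated one on the piperazine

This account rests on a few compounds, and the source may have more. Where it says the series, first, only, none or still open, it means among the compounds named here.

Measured compounds in a physicochemical assay for lipophilicity, in phosphate buffer, measured as octanol-water partition, at pH 7.4; on this read-out lower numbers stand for lower lipophilicity and higher numbers for higher lipophilicity:
- compound 1, `O=C(CN1CCN(c2ccc(F)cc2)CC1)Nc1nc2c(s1)CCCC2`: 4.5
- compound 2, `O=C(CN1CCN(c2ccc(F)cn2)CC1)Nc1nc2c(o1)CCCC2`: 2.7
- compound 3, `Cc1ccc(N2CCN(CC(=O)Nc3nc4c(s3)CCCC4)CC2)cc1`: 4.8

Compound 1 sits close to compound 3, the gap between them lying within the scatter of this assay, while compound 2 stands far below both, beyond the scatter. Among the compounds with values here, the one measured step between neighbours, a number 0.30 log units higher from compound 1 to compound 3 (within the scatter), is small and concerns a different part of the molecule than the change considered here.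

The next compound, compound 4 with structure `O=C(CN1CCN(C2CCCCC2)CC1)Nc1nc2c(s1)CCCC2`, differs from compound 1 in a single place: cyclohexyl in place of 4-fluorophenyl on an amine nitrogen in a ring. Within the data shown here, no measured pair covers this kind of exchange, so the expectation rests on the structures alone. The group that leaves and the group that enters are of similar size, but one is an aromatic ring and the other is not, and the ring nitrogen that bears the group is altered in its surroundings. Compound 4 is therefore expected to show a step of a number 1.20 log units lower from compound 1 to compound 4 (beyond the scatter) in this assay, that is a move downward beyond the scatter. The estimated value for compound 4 is 3.3, within a range from 2.3 to 4.3.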

Compound 4, distribution coefficient: 3
Compound 4: the middle estimate sits 0.30 log units above what was measured; measured number inside the range.
By their numbers in this assay, from the lowest: compounds 2 and 4 (each within the scatter of the next); then compounds 1 and 3 (each within the scatter of the next).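

In this assay the exchange on this amine nitrogen in a ring gives a number 1.50 log units lower from compound 1 to compound 4 (beyond the scatter) and a number 1.80 log units lower from compound 3 to compound 4 (beyond the scatter) with either aromatic group as the starting point. The earlier step, a number 0.30 log units higher from compound 1 to compound 3 (within the scatter) for methyl in place of fluoro on an aromatic carbon, stayed within the scatter, whereas replacing the whole aromatic ring with cyclohexyl goes well beyond it. Among compound 1, compound 3 and compound 4, then, the read-out follows the kind of ring on this nitrogen much more closely than the small group on the aromatic ring.

Still open, from the compounds shown here alone, is whether a longer chain such as butyl, or a cyclohexyl carrying an amine or a carboxylic acid, would give a step of similar size on this nitrogen. There is also no evidence at hand that explains the size of these steps.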